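A few compounds are considered here, and "the series" means these few. Any claim that something is new, unique, unknown or untested is made for them only; others in the source may bear on it.

Compound 2, `COCc1cccc(CNC(=O)c2nn(-c3ccc(F)cc3)c(OC[C@@H](O)C[C@@H](O)CC(=O)O)c2C(C)C)c1`, carries a shared core with compound 1, `Cc1ccccc1CNC(=O)c1nn(-c2ccc(F)cc2)c(OC[C@@H](O)C[C@@H](O)CC(=O)O)c1C(C)C`, and the two differ only in the group on the benzyl ring. In an assay on microsomes from liver for inhibition of 3-hydroxy-3-methylglutaryl-coenzyme A reductase (Rattus norvegicus) (a lower number here means a stronger inhibitor, a higher number a weaker inhibitor), compound 1 gives 17 nM, and in the same assay compound 2 gives 31 nM; the step of a 1.8-fold higher number from compound 1 to compound 2 (0.26 log units; within the scatter) leaves the two numbers alongside each other. Compound 3, `CC(C)c1c(C(=O)NCc2cccc(Cl)c2)nn(-c2ccc(F)cc2)c1OC[C@@H](O)C[C@@H](O)CC(=O)O`, arises from compound 2 by chloro in place of methoxymethyl on an aromatic carbon. For the measured compounds named here, only one measured step touches the same position, the exchange of one benzyl substituent for another from compound 1 to compound 2, and it stayed within the scatter, so there is no measured ground for a shift beyond the scatter in this assay. Compound 3 is therefore expected to give 25 nM in this assay, within a range of 10 nM to 70 nM, which is a step of a 1.2-fold lower number from compound 2 to compound 3 (0.09 log units; within the scatter) from compound 2.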

Compound 3, half-maximal inhibitory concentration: 5.4 nM
Compound 3: middle estimate off by 4.6-fold (0.67 log units), on the high side; measured number outside the range, below it.
By their numbers in this assay, from the lowest: compound 3; then compounds 1 and 2 (each within the scatter of the next).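

For the compounds shown here, with chloro on this aromatic carbon, a change at the benzyl ring moves the number beyond the scatter for the first time: in this assay there is a 5.7-fold lower number from compound 2 to compound 3 (0.76 log units; beyond the scatter), as a methoxymethyl group of 3 heavy atoms and 1 hydrogen-bond acceptor gives way to a chloro group of 1 heavy atom and no acceptor. The 3-chlorobenzyl compound also stands apart from the 2-methylbenzyl compound, with a 3.1-fold lower number from compound 1 to compound 3 (0.50 log units; beyond the scatter), so compound 3 has the lowest number of the three. Nothing given here accounts for this difference.

The step from compound 1 changes both the group and its place on the ring, so the compounds shown do not separate those two changes. As far as these compounds go, whether bromo, methoxy or trifluoromethyl on the same aromatic carbon would match chloro also remains open.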